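The compounds below may be only part of what the source reports. "The series", "measured", "known", "first", "only" and "open" are said of these compounds alone.

Notes on the series, read in an ADME assay (liver) for metabolic stability, with Liver microsome (Homo sapiens) as the target, read by LC-MS, using microsomes and NADPH, with a stated time of 5 min, at 37 degrees C; on this read-out higher numbers stand for fast clearance and lower numbers for slow clearance. Within the data shown here, compound 1 `CCn1c([C@@H](C)NS(=O)(=O)c2ccc(F)cc2)nc2ccc(C(F)(F)F)cc21` gives 26 mL.min-1.g-1, the only true number so far. Compound 2 `CCn1c([C@@H](C)NS(=O)(=O)c2cccc(Cl)c2)nc2ccc(C(F)(F)F)cc21` reads > 100 mL.min-1.g-1, which is a limit of the assay and not a number. On these data alone, compound 3 `CCn1c([C@@H](C)NS(=O)(=O)c2ccc(CC(C)C)cc2)nc2ccc(C(F)(F)F)cc21` reads > 100 mL.min-1.g-1, also only a limit, so its true position is unknown.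

Compound 4 `CCn1c([C@@H](C)NS(=O)(=O)c2c(F)cc(F)cc2F)nc2ccc(C(F)(F)F)cc21` is unmeasured and differs from compound 3 as follows: 2,4,6-trifluorophenyl in place of 4-isobutylphenyl on a sulfonyl sulfur. Among the measured compounds shown here, the closest precedent is an at least 3.8-fold higher number from compound 1 to compound 3 (0.58 log units; beyond the scatter), a replacement of fluoro by isobutyl on the aromatic ring, and the new step runs the other way. The step of an at least 3.8-fold higher number from compound 1 to compound 2 (0.58 log units; beyond the scatter) is a caution, since the 3-chlorophenyl of compound 2 carries a halogen yet goes against any simple halogen trend. The step that the two limits leave unreadable from compound 2 to compound 3 offers no guidance.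

A fall is expected, and the expected step is an at least 3.1-fold lower number from compound 3 to compound 4 (0.49 log units; beyond the scatter), beyond the scatter if the number is read. The expectation rests on compound 1 at 26 mL.min-1.g-1, the nearest measured fluorinated analogue. For compound 4 the estimate is 32 mL.min-1.g-1, with an expected range of 12 mL.min-1.g-1 to 85 mL.min-1.g-1.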

Compound 4, intrinsic clearance in microsomes: 19 mL.min-1.g-1
The estimate for compound 4 lay 1.7-fold (0.23 log units) above the measured number, and the stated range covers the measured number.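

On the aryl group at the sulfonyl sulfur, this assay now gives a second true number in the series, from 2,4,6-trifluorophenyl, with an at least 5.2-fold lower number from compound 3 to compound 4 (0.72 log units; beyond the scatter) and an at least 5.2-fold lower number from compound 2 to compound 4 (0.72 log units; beyond the scatter). The two fluorinated groups do not separate on this read-out, with a 1.4-fold lower number from compound 1 to compound 4 (0.14 log units; within the scatter). Among the compounds shown, both fluorinated aryl groups give true numbers, while 4-isobutylphenyl and 3-chlorophenyl do not, and compound 2 shows that a halogen on this ring is not enough for a true number.

On these data alone, the step between compound 2 and compound 3 cannot be read, and the full size of the steps to compound 4 from those two compounds stays open: the limit of > 100 mL.min-1.g-1 in this assay, at which 2 of the 4 values shown sit. Also open is how this position reads with a phenyl carrying an amine or a carboxylic acid, or with a short alkyl chain in place of the aryl group.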